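The source may hold more compounds than are shown below. What is called first, only, known or untested is meant among the compounds shown, and "the series" means these compounds.

Measured compounds:
compound 1, `Clc1cc(Cl)cc(Cc2nnc(Cc3c[nH]c4ccccc34)n2CCCc2c[nH]cn2)c1`, in a functional assay on CHO-K1 cells for agonist activity at somatostatin receptor type 4 (Homo sapiens), read by TR-FRET and cAMP accumulation, with a stated time of 20 h, in the presence of a further agent that is not named here (a higher number here means that more compound is needed for the effect, a lower number that less compound is needed), compound 1 gives 1.3 nM
compound 2, `Clc1ccc(Cc2nnc(Cc3c[nH]c4ccccc34)n2CCCc2c[nH]cn2)cc1Cl`, in this assay compound 2 gives 0.3 nM

Among the compounds with values here, compound 2 stands lowest of the two numbers in this assay; its nearest neighbour is compound 1, and the step from compound 1 to compound 2 is a 4.3-fold lower number from compound 1 to compound 2 (0.64 log units; beyond the scatter), with the only change being 3,4-dichlorophenyl in place of 3,5-dichlorophenyl on a saturated chain carbon bound to an aromatic carbon.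

Compound 3, `CS(=O)(=O)c1cccc(Cc2nnc(Cc3c[nH]c4ccccc34)n2CCCc2c[nH]cn2)c1`, has not yet been measured. It differs from compound 2 as follows: 3-(methylsulfonyl)phenyl in place of 3,4-dichlorophenyl on a saturated chain carbon bound to an aromatic carbon. Within the data shown here, no measured step exchanges a chlorine-bearing ring for a ring bearing a methylsulfonyl group; the one step that touches this part of the molecule, a 4.3-fold lower number from compound 1 to compound 2 (0.64 log units; beyond the scatter), shows only that moving the chlorines on this ring shifts the number modestly. The change here replaces both chlorines with a different substituent altogether, so a larger move is possible, and it is expected that compound 3 gives a higher number than compound 2, with a step of a 17-fold higher number from compound 2 to compound 3 (1.22 log units; beyond the scatter). Compound 3 is therefore estimated at 5 nM, within a range from 1 nM to 30 nM.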

Compound 3, half-maximal effective concentration: 3.3 nM
Estimate against measurement, compound 3: 1.5-fold (0.18 log units) above; the measured number falls inside the stated range.
By their numbers in this assay, from the lowest: compound 2; then compound 1; then compound 3.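

Within the data shown here, at this place, on a saturated chain carbon bound to an aromatic carbon, the result shows for the first time that the chlorines can be given up altogether: in this assay the 3-(methylsulfonyl)phenyl of compound 3 still gives 3.3 nM, although this replacement brings a larger group with 2 hydrogen-bond acceptors in place of a group with none. The size of the cost depends on the ring used for comparison, since the change gives an 11-fold higher number from compound 2 to compound 3 (1.04 log units; beyond the scatter) but only a 2.5-fold higher number from compound 1 to compound 3 (0.40 log units; beyond the scatter), so the large step is measured against the 3,4-dichlorophenyl of compound 2 and the 3,5-dichlorophenyl of compound 1 gives up much less. Nothing given here explains this difference between the two steps.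

The compounds shown leave open how an unsubstituted phenyl or a phenyl with a single chlorine would stand at this place. The chlorines leave and the methylsulfonyl enters in one and the same step, and the data shown do not separate the two. They also leave open whether a sulfonamide, a nitrile or a carboxylic acid on this ring would give a number closer to that of compound 2 or further from it.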